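The compounds below may be only part of what the source reports. "The series", "measured", "known", "first", "only" and "open" are said of these compounds alone.

In a functional assay on HOS cells (Homo sapiens) for antiproliferative activity, read by sulforhodamine B assay (a higher number here means a weaker inhibitor of growth, a lower number a stronger inhibitor of growth), compound 1 `CCC[C@H]1O[C@H](COCc2ccccc2)[C@@H](OCc2ccccc2)[C@H](OCc2ccccc2)[C@H]1O` gives a measured 23600 nM. Compound 2 `CCCCCCCCCCCCCCCOC[C@H]1O[C@@H](CCC)[C@H](O)[C@@H](OCCCCCCCCCCCCCCC)[C@@H]1OCCCCCCCCCCCCCCC` returns only a limit, > 50000 nM, so no exact number fixes its place on this scale. Compound 3 `CCCCCCCCCCCCCCCOC[C@H]1O[C@H](CCC)[C@H](O)[C@@H](OCCCCCCCCCCCCCCC)[C@@H]1OCCCCCCCCCCCCCCC` has the same connectivity as compound 2 and departs from it in configuration alone: the two compounds have the same atoms and bonds and differ only in configuration as drawn: 1 of 5 stereo elements differ; a stereocentre at a saturated ring carbon is drawn S in compound 2 and R in compound 3. Going by the values given here, no measured pair isolates a change of this kind, so the data give no direct size for it, and no shift beyond the usual scatter is expected in this assay. This expectation rests on compound 2, whose reading of > 50000 nM is a limit. The expected change, a number no higher from compound 2 to compound 3 (the limit leaves the size open), is estimated to lie within the scatter, and a second limit is the likeliest report. For compound 3 the estimate is 50000 nM, with an expected range of 22000 nM to 100000 nM.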

Compound 3, concentration for 50% growth inhibition: 29900 nM
Beside the measured number, compound 3's estimate is 1.7-fold (0.22 log units) above it; low and high end bracket the measured number.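

In this assay, a single stereocentre at a saturated ring carbon now has its first measured step: an at least 1.6-fold lower number from compound 2 to compound 3 (0.22 log units; that floor lies within the scatter). Compound 2 stands at a limit, > 50000 nM, so this step is only a floor, and the true size of the change may or may not exceed the scatter. Any real gap between the two readings can be assigned to this one stereocentre alone: the fact that compounds 2 and 3 differ only in the configuration as drawn

As far as these compounds go, the exact reading of compound 2 remains open, and with it the full size of the step, as does whether the same inversion would matter in the benzyl ether series of compound 1. From the compounds shown here alone, how an amine or a carboxylic acid on the shared core would read in this assay, at either configuration, also remains open.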